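This account rests on a few compounds, and the source may have more. Where it says the series, first, only, none or still open, it means among the compounds named here.

In an ADME assay on Vero cells (Chlorocebus sabaeus) for cytotoxicity, read by neutral red uptake, with a stated time of 48 h (on this read-out higher numbers stand for weaker inhibition and lower numbers for stronger inhibition), three compounds built on a shared core have been tested. Compound 1 `CN(C)c1nc(Cl)nc2c1ncn2CCCNc1ccnc2cc(Cl)ccc12` gives > 11400 nM, which is a limit of the assay. Compound 2 `CCN(CC)c1nc(Cl)nc2c1ncn2CCCNc1ccnc2cc(Cl)ccc12` gives > 10700 nM, which is also a limit. Compound 3 `Clc1ccc2c(NCCCn3cnc4c(N5CCCC5)nc(Cl)nc43)ccnc2c1` gives > 10700 nM, again only a limit, so it has no number of its own to start from. Compound 4 `Clc1ccc2c(NCCCn3cnc4c(N5CCCCC5)nc(Cl)nc43)ccnc2c1` carries piperidin-1-yl in place of pyrrolidin-1-yl on an aromatic carbon. The measured steps that bear on this change are a step that the two limits leave unreadable from compound 1 to compound 2, a step that the two limits leave unreadable from compound 1 to compound 3 and a step that the two limits leave unreadable from compound 2 to compound 3, and none has a readable size. In this assay, the expected result is therefore no change beyond the scatter, with an estimated at least 1.0-fold lower number from compound 3 to compound 4 (0.00 log units; that floor lies within the scatter). The estimate for compound 4 is 10500 nM, with an expected range from 5000 nM to 20000 nM.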

Compound 4, half-maximal inhibitory concentration: > 10400 nM
Compound 4: only a limit was reported; the forecaster's own chance of this, stated with the estimate: 80%; the middle value does not contradict the limit.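

In this assay, within the data shown here, compound 4 gives > 10400 nM, which is a limit, so no step linking it to compound 1, compound 2 or compound 3 can be read. The compounds shown leave open whether dimethylamino, diethylamino, pyrrolidin-1-yl and piperidin-1-yl differ at all in this assay.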